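This account rests on a few compounds, and the source may have more. Where it says the series, first, only, none or still open, it means among the compounds named here.

Notes on the series. Compound 1 `Nc1cccc(S(=O)(=O)Oc2ccc(-c3cncn3C3CCN(C(=O)c4ccc(Cl)c(C(F)(F)F)c4)CC3)cc2)c1` and compound 2 `O=C(c1ccc(Cl)c(C(F)(F)F)c1)N1CCC(n2cncc2-c2ccc(OS(=O)(=O)c3cccc4cnccc34)cc2)CC1` share a core and differ only at the sulfonyl sulfur. In an assay on HEK293 cells for antagonist activity at P2X purinoceptor 7 (Homo sapiens), read by fluorescence, with a stated time of 2 h (a higher number here means a weaker inhibitor, a lower number a stronger inhibitor), compound 1 gives 565 nM, and compound 2 gives 45 nM. Within the data shown here, the step of a 13-fold lower number from compound 1 to compound 2 (1.10 log units; beyond the scatter) is the only measured step in the set. On the two numbers shown, compound 2 stands lowest; its nearest neighbour, compound 1, sits that step above it.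

Compound 3 `CS(=O)(=O)c1ccc(C(=O)N2CCC(n3cncc3-c3ccc(OS(=O)(=O)c4cccc5cnccc45)cc3)CC2)cc1` is not yet measured. It differs from compound 2 at another place: 4-(methylsulfonyl)phenyl in place of 4-chloro-3-(trifluoromethyl)phenyl on a carbonyl carbon. Among the measured compounds shown here, the one measured step concerns the aryl on the sulfonyl sulfur and leaves the carbonyl carbon untouched, so no measured step bears on this change, and the numbers give no direct guide to its size or direction in this assay. With nothing measured at this position, a modest shift toward a higher number is expected rather than a large one: compound 3 is estimated at 200 nM, with a range of 60 nM to 1500 nM. The expected step is a 4.4-fold higher number from compound 2 to compound 3 (0.65 log units; beyond the scatter), though a result within the scatter of compound 2 would not surprise.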

Compound 3, half-maximal inhibitory concentration: 25 nM
For compound 3 the middle estimate is 8.0-fold (0.90 log units) above the measured one; measured number below the stated range.
By their numbers in this assay, from the lowest: compounds 3 and 2 (each within the scatter of the next); then compound 1.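

The carbonyl carbon is now a position with a measured step: 4-(methylsulfonyl)phenyl in place of 4-chloro-3-(trifluoromethyl)phenyl gives a 1.8-fold lower number from compound 2 to compound 3 (0.26 log units; within the scatter) in this assay, so this exchange, which removes the chlorine and the three fluorines and brings in 2 hydrogen-bond acceptors, leaves the two compounds indistinguishable in this read-out. Within the compounds shown, the two positions therefore read differently, as the change on the sulfonyl sulfur gives a 13-fold lower number from compound 1 to compound 2 (1.10 log units; beyond the scatter), a step beyond the scatter, whereas the change on the carbonyl carbon stays within it. Nothing available explains why this aryl exchange leaves the number within the scatter.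

Among these compounds, open is whether the same exchange on the carbonyl carbon would read alike with 3-aminophenyl rather than isoquinolin-5-yl on the sulfonyl sulfur, as the only step at the carbonyl carbon carries isoquinolin-5-yl. Also open, from the compounds shown here alone, is how far the position extends to other groups, such as a phenyl bearing a carboxylic acid or an amine, or a saturated cyclohexyl ring in place of the aryl.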